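The source may report more compounds than this note shows. Statements on the series, on what has been measured and on what is new or still open speak of the compounds shown alone.

Within the data shown here, compound 1 `COc1ccc(C(=O)Nc2ccccn2)cc1OC1CCCC1` gives 1000 nM in an assay on isolated protein for inhibition of phosphodiesterase 4A (Sus scrofa) (a higher number here means a weaker inhibitor, a lower number a stronger inhibitor), the highest number among the three measured members. Compound 2 `COc1ccc(C(=O)Nc2c(F)c(F)nc(F)c2F)cc1OC1CCCC1` gives 550 nM in this assay, a number within the scatter of compound 1. Compound 3 `COc1ccc(C(=O)Nc2c(Cl)c(F)nc(F)c2Cl)cc1OC1CCCC1` gives 20 nM in this assay, well below compound 1 and beyond the scatter. Compound 4 `COc1ccc(C(=O)Nc2c(C)nsc2C)cc1OC1CCCC1` is not yet measured; it differs from compound 1 by 3,5-dimethyl-1,2-thiazol-4-yl in place of pyridin-2-yl on an amide-type nitrogen, on the shared core. The ring that enters is a five-membered aromatic ring with 2 hetero atoms, where the ring that leaves is six-membered with 1 hetero atom. The expected step is a 5.0-fold lower number from compound 1 to compound 4 (0.70 log units; beyond the scatter), toward a lower number and modestly beyond the scatter. Compound 4 is estimated at 200 nM, with a range from 50 nM to 800 nM.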

Compound 4, half-maximal inhibitory concentration: 500 nM
Estimate against measurement, compound 4: 2.5-fold (0.40 log units) below; the measured number falls inside the stated range.
By their numbers in this assay, from the lowest: compound 3; then compounds 4, 2 and 1 (each within the scatter of the next).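

In this assay, the swap to 3,5-dimethyl-1,2-thiazol-4-yl gives a 2.0-fold lower number from compound 1 to compound 4 (0.30 log units; within the scatter), so this place on the amide-type nitrogen takes a five-membered aromatic ring instead of pyridin-2-yl with no readable difference. The earlier compounds shown here all carry six-membered rings here. No data bearing on the cause accompany this step. It remains open whether the two methyl groups matter, since the compounds shown do not separate them from the ring itself. The unsubstituted 1,2-thiazol-4-yl or the diethyl counterpart would address that.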